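Replacing the pyridinyl arm: a fluorophenyl analogue in CCRF-CEM cells

The source may hold more compounds than are shown below. What is called first, only, known or untested is meant among the compounds shown, and "the series" means these compounds.

Compound 1 `OC[C@H]1OC(n2cnc3c(-c4cc[nH]c4)ncnc32)[C@H](O)[C@@H]1O` in a functional assay on CCRF-CEM cells (Homo sapiens) for inhibition (on this read-out lower numbers stand for stronger inhibition and higher numbers for weaker inhibition), gives 1030 nM.
Compound 2 `OC[C@H]1OC(n2cnc3c(-c4ccoc4)ncnc32)[C@H](O)[C@@H]1O` in this assay gives 1650 nM.
Compound 3 `OC[C@H]1OC(n2cnc3c(-c4ccccn4)ncnc32)[C@H](O)[C@@H]1O` in this assay gives 900 nM.

Three compounds share a core and differ only in the aromatic group attached to it. Compound 3 shows the lowest of the three numbers, but its neighbours sit close: a 1.1-fold lower number from compound 1 to compound 3 (0.06 log units; within the scatter) and a 1.8-fold lower number from compound 2 to compound 3 (0.26 log units; within the scatter), so compound 3 cannot be called stronger than compound 1 or compound 2. The remaining step, a 1.6-fold higher number from compound 1 to compound 2 (0.20 log units; within the scatter), is also within the scatter. Every swap of one five- or six-membered aromatic group for another has so far left the read-out essentially unchanged.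

Compound 4 `OC[C@H]1OC(n2cnc3c(-c4ccc(F)cc4)ncnc32)[C@H](O)[C@@H]1O` continues this series with the change (4-fluorophenyl in place of pyridin-2-yl on an aromatic carbon). Among the compounds with values here, no measured step bears directly on this exchange; the three earlier steps, all within the scatter, are the only guide, and they suggest that the aromatic group at this position has little hold on the number. Compound 4 is therefore expected to move by a 1.2-fold higher number from compound 3 to compound 4 (0.09 log units; within the scatter), that is, no step beyond the scatter. For compound 4 the estimate in this assay is 1100 nM, with a likely range from 400 nM to 3000 nM.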

Compound 4, half-maximal inhibitory concentration: 700 nM
Beside the measured number, compound 4's estimate is 1.6-fold (0.20 log units) above it, within the range that was stated.
By their numbers in this assay, from the lowest: compounds 4, 3, 1 and 2 (each within the scatter of the next, the first and the last beyond it).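

Exchanging pyridin-2-yl, with its hydrogen-bond acceptor, for 4-fluorophenyl, a ring of carbon only with no such acceptor, and adding a fluorine leaves this assay without a readable change: a 1.3-fold lower number from compound 3 to compound 4 (0.11 log units; within the scatter), and likewise a 1.5-fold lower number from compound 1 to compound 4 (0.17 log units; within the scatter). The aromatic group at this position is nevertheless not wholly without consequence, since the series now holds its first step beyond the scatter, though only a modest one: a 2.4-fold lower number from compound 2 to compound 4 (0.37 log units; beyond the scatter). That single pair is the only separation among the four compounds, so compound 4 cannot be called stronger than compound 1 or compound 3, and nothing available accounts for the gap between the 4-fluorophenyl and furan-3-yl groups.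

Every group shown on this aromatic carbon is a single aromatic ring, so the compounds leave open how the read-out responds to an amine, a carboxylic acid or a longer alkyl chain at the same place. They also leave open what the fluorine contributes to compound 4, as unsubstituted phenyl and other placements of the fluorine on the ring are not among the compounds shown.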